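The source may hold more compounds than are shown below. What is called first, only, known or untested is meant among the compounds shown, and "the series" means these compounds.

Measured compounds:
- compound 1, `COc1cc2c(Oc3ccc(NC(=O)C4(c5nnc(-c6ccc(F)cc6)o5)CC4)cc3F)ccnc2cc1OCCCN1CCCC1`: 2340 nM
- compound 2, `COc1cc2c(Oc3ccc(NC(=O)c4nnc(-c5ccc(F)cc5)o4)cc3)ccnc2cc1OCCCN1CCC(C)CC1`: 3810 nM

Of the compounds shown here, two have so far been tested in a functional assay on PC-3 cells (Homo sapiens) for antiproliferative activity, read by MTT assay, with a stated time of 72 h; on this read-out higher numbers stand for weaker inhibition and lower numbers for stronger inhibition. Compound 1 gives 2340 nM, the lower of the two numbers. Compound 2 gives 3810 nM, and the gap between the two lies within the usual scatter of this assay, so the two cannot be ranked against each other. Compound 2 also differs from compound 1 in several places at once, so it offers no single-change comparison.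

Compound 3, `COc1cc2c(Oc3ccc(NC(=O)C4(c5nnc(-c6ccc(F)cc6)o5)CC4)cc3F)ccnc2cc1OCCCN1CCCCC1`, differs from compound 1 in one place only: piperidin-1-yl in place of pyrrolidin-1-yl on a saturated chain carbon, three bonds along the chain from an oxygen on an aromatic ring. For the measured compounds named here, no measured pair shows this change, so there is nothing to read a direction from. The step of a 1.0-fold lower number from compound 1 to compound 3 (0.01 log units; within the scatter) is therefore expected to be none beyond the scatter. Compound 3 is expected to give 2300 nM in this assay, within a range from 900 nM to 6000 nM.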

Compound 3, half-maximal inhibitory concentration: 590 nM
The estimate for compound 3 lay 3.9-fold (0.59 log units) above the measured number; measured number outside the range, below it.
By their numbers in this assay, from the lowest: compound 3; then compounds 1 and 2 (each within the scatter of the next).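

In this assay, the group at the end of the propyl chain turns out to matter: replacing 3-(pyrrolidin-1-yl)propyl with 3-(piperidin-1-yl)propyl gives a 4.0-fold lower number from compound 1 to compound 3 (0.60 log units; beyond the scatter), a modest step but one beyond the scatter. For the compounds shown here, this is the first comparison here in which only one place differs, so the step can be tied to the swap of a five-membered ring for a six-membered one, with the rest of the molecule unchanged. No independent measurement bears on the reason for this step.

This single pair cannot show whether the same swap would have a similar effect on a different core. It also leaves open how a morpholine ring, a dimethylamino group or a seven-membered azepane ring at the chain end would compare, and whether the shorter 2-(piperidin-1-yl)ethyl chain would give a similar number.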